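A few compounds are considered here, and "the series" means these few. Any claim that something is new, unique, unknown or untested is made for them only; others in the source may bear on it.

The account follows the step from compound 3 `CN(C)C(=O)c1sc2nc(-c3ccccc3)cc(C(F)(F)F)c2c1N` to compound 4 `Nc1c(C(=O)NCc2ccccc2)sc2nc(-c3ccccc3)cc(C(F)(F)F)c12` in an ADME assay on Huh-7 cells (Homo sapiens) for cytotoxicity, read by MTT assay, with a stated time of 72 h; on this read-out higher numbers stand for lower toxicity in this test and lower numbers for higher toxicity in this test. Compound 3 reaches only a limit of the measurement and gives > 20000 nM. Compound 1 `CCOC(=O)c1sc2nc(-c3cccs3)cc(C(F)(F)F)c2c1N` likewise reaches a limit, giving > 20000 nM. Compound 2 `Nc1c(C(=O)NCc2cccs2)oc2nc(-c3ccccc3)cc(C(F)(F)F)c12` also reaches a limit, giving > 20000 nM. For the measured compounds named here, compound 3 thus stands together with the other two at the limit of > 20000 nM in this assay, at which 3 of the 3 values shown sit; none of the three has a number, only a limit, so no measured step between any pair of them is known. The change from compound 3 to compound 4 is benzylamino in place of dimethylamino on a carbonyl carbon. Going by the values given here, no measured pair of compounds differs in one place, so nothing among them tells the size of such a change; with every value sitting at the same limit, the expected step of a number no higher from compound 3 to compound 4 (the limit leaves the size open) is none beyond the scatter. Compound 4 is therefore expected to give about 20000 nM in this assay, between 8000 nM and 50000 nM, most likely reported again as a limit.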

Compound 4, half-maximal cytotoxic concentration: > 20000 nM
Compound 4 was reported as a limit (the forecaster's own chance of this, stated with the estimate: 80%); the middle value lies on the limit itself.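

In this assay compound 4 gives > 20000 nM, which is a limit and not a number. For the compounds shown here, compound 3 is also reported only as a limit, so no step from compound 3 to compound 4 can be read. The compounds shown leave open what benzylamino in place of dimethylamino on a carbonyl carbon does to this read-out, since all of them share one limit: the limit of > 20000 nM in this assay, at which 4 of the 4 values shown sit.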